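Bromo in Place of Nitro on the Aromatic Ring

The source may hold more compounds than are shown below. What is called first, only, known or untested is meant among the compounds shown, and "the series" means these compounds.

Compound 1, `CC(=O)Nc1ccc(CN2CCC=C(CCC(=O)NO)C2=O)cc1`: "not determined" (no result reported)
Compound 2, `Cc1cccc(CN2CCC=C(CCC(=O)NO)C2=O)c1`: > 10000 nM
Compound 3, `O=C(CCC1=CCCN(Cc2ccc([N+](=O)[O-])cc2)C1=O)NO`: > 10000 nM

The three measured compounds share one core and differ in the group on the aromatic ring. In a functional assay on HCT-15 cells (Homo sapiens) for inhibition, read by sulforhodamine B assay (on this read-out higher numbers stand for weaker inhibition of growth and lower numbers for stronger inhibition of growth), compound 2 reaches only a limit, > 10000 nM. Compound 3 likewise gives only a limit, > 10000 nM. For compound 1 no number is reported, "not determined" (no result reported). Compound 3 therefore stands at the limit of > 10000 nM in this assay, at which 2 of the 3 values shown sit, and the numbers shown do not set it apart from compound 2. Compound 4, `O=C(CCC1=CCCN(Cc2ccc(Br)cc2)C1=O)NO`, differs from compound 3 by bromo in place of nitro on an aromatic carbon. For the measured compounds named here, no measured pair differs in a single place, so no step size is known from the data. The expected step that the limit leaves unreadable from compound 3 to compound 4 is none beyond the scatter. Compound 4 is estimated at 12000 nM, within 3000 nM to 50000 nM.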

Compound 4, concentration for 50% growth inhibition: 1720 nM
Estimate against measurement, compound 4: 7.0-fold (0.84 log units) above; the measured number lies below the stated range.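

In this assay, for the compounds shown here, this aromatic carbon proves sensitive to the group it carries, which the earlier compounds could not show: bromo in place of nitro gives an at least 5.8-fold lower number from compound 3 to compound 4 (0.76 log units; beyond the scatter). The change to 4-bromophenyl from 3-methylphenyl gives an at least 5.8-fold lower number from compound 2 to compound 4 (0.76 log units; beyond the scatter). Both steps start from a limit, so they give only a minimum size: the limit of > 10000 nM in this assay, at which 2 of the 4 values shown sit.

The compounds shown leave open whether this gain is specific to bromo, since chloro or an amine on the same aromatic carbon would be needed to tell. They also leave open how a 3-bromophenyl group would compare with the 4-bromophenyl group.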